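Adding a Methoxy to Compound 1: What to Expect

This account rests on a few compounds, and the source may have more. Where it says the series, first, only, none or still open, it means among the compounds named here.

Measured so far:
compound 1, `COc1cc2ccc(=O)oc2cc1OCC(=O)c1ccccc1`, gives 83.6%
compound 2, `COc1cc2ccc(=O)oc2cc1OCC(O)CN1CCCCC1`, gives 80.7%
compound 3, `COc1cc2ccc(=O)oc2cc1OCC1CO1`, gives 95.5%

All three compounds share one core and differ only in the side chain attached through the ether oxygen. They were tested in a functional assay on HUVEC cells (Homo sapiens) for inhibition, read by MTT assay, with a stated time of 24 h, tested at 100 uM; a lower number here means less inhibition of growth, a higher number more inhibition of growth at the concentration tested. Compound 1 gives 83.6%, the second highest of the three numbers. Compound 2 gives 80.7%, a number within the usual scatter of that of compound 1, so the two cannot be told apart. Compound 3 gives 95.5%, a number higher than that of compound 1 by a margin beyond the scatter.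

The unmeasured compound 4, `COc1ccc(C(=O)COc2cc3oc(=O)ccc3cc2OC)cc1`, comes from compound 1 by a single change:
methoxy in place of hydrogen on an aromatic carbon
For the measured compounds named here, no two measured compounds differ by this change alone, so nothing measured shows how a methoxy at this place plays out in this assay. On the measured compounds alone, a step of a number 1.6 percentage points lower from compound 1 to compound 4 (within the scatter) is expected, which is none beyond the scatter in either direction. Compound 4 is therefore estimated at 82%, with a likely range from 68% to 94%.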

Compound 4, percent growth inhibition at one concentration: 85.6%
For compound 4 the middle estimate is 3.6 percentage points below the measured one, within the range that was stated.
By their numbers in this assay, from the lowest: compounds 2, 1, 4 and 3 (each within the scatter of the next, the first and the last beyond it).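

Measured in this assay, the change from phenyl to 4-methoxyphenyl gives a number 2 percentage points higher from compound 1 to compound 4 (within the scatter) and so compound 1 and compound 4 cannot be told apart. For the compounds shown here, this is the first direct reading of this change: a methoxy can stand on this aromatic carbon, para to a large group, without moving the growth inhibition beyond the usual scatter at the single concentration tested. No supporting measurement bears on why the two compounds read alike, so this result records only what happened and offers no explanation.

This single step leaves open whether other groups on the same carbon, such as an amine, a carboxylic acid or a longer chain like ethoxy, would also stay within the scatter or would produce a clear step up or down. It also cannot show whether a methoxy on another carbon of this ring would behave in the same way, or whether compound 1 and compound 4 would remain indistinguishable at lower concentrations.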